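The source may hold more compounds than are shown below. What is called first, only, known or untested is meant among the compounds shown, and "the series" means these compounds.

The study brings together three measured compounds and one still to be tested in a functional assay on the whole organism with Rattus norvegicus as the target; on this read-out higher numbers stand for an effect only at larger amounts of compound and lower numbers for an effect already at smaller amounts. Compound 1, `Nc1ccc2nc(N)sc2c1`, is the bare shared core with two amino groups. In this assay compound 1 reaches only a limit, > 10 mg/kg. Compound 2, `CCCCCCCc1ccc2nc(N)sc2c1`, carries a heptyl chain on the same core. For compound 2 the outcome is likewise a limit, > 10 mg/kg. Compound 3, `CN(C)S(=O)(=O)CCn1c(=N)sc2cc(OC(F)(F)F)ccc21`, bears a trifluoromethoxy group and a dimethylsulfamoyl-bearing chain on the ring nitrogen. In this assay compound 3 also stands at a limit, > 10 mg/kg. Compound 3 therefore sits where every measured value in the set sits: the limit of > 10 mg/kg in this assay, at which 3 of the 3 values shown sit. Within the data shown here, no two measured compounds differ in a single place, so no step between them can be drawn.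

Compound 4, `N=c1sc2cc(OC(F)(F)F)ccc2n1CCN1CCCCC1`, is the unmeasured member. The change from compound 3 is piperidin-1-yl in place of dimethylsulfamoyl on a saturated chain carbon, two bonds along the chain from an aromatic nitrogen. Among the measured compounds shown here, no measured step speaks to this change, and the expectation rests on compound 3 alone, which in this assay gives a limit, > 10 mg/kg.

The account expects compound 4 to give about 15 mg/kg, with a range from 3 mg/kg to 60 mg/kg. The expected step is a step that the limit leaves unreadable from compound 3 to compound 4, that is, no change beyond the scatter, with a limit again the most likely report.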

Compound 4, dose for half-maximal effect: 2 mg/kg
Compound 4: middle estimate off by 7.5-fold (0.88 log units), on the high side; measured number below the stated range.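

In this assay, among these compounds, compound 4 gives 2 mg/kg, the only number in the set that is not a limit, so a compound carrying a group at this place on the chain can show an effect in the whole animal. Piperidin-1-yl in place of dimethylsulfamoyl, on a saturated chain carbon, two bonds along the chain from an aromatic nitrogen, gives an at least 5.0-fold lower number from compound 3 to compound 4 (0.69 log units; beyond the scatter), a step beyond the scatter that can be stated only as a minimum size. Compound 4 is the only compound in the set that stands off the shared limit: the limit of > 10 mg/kg in this assay, at which 3 of the 4 values shown sit.

Among the compounds shown here, the single step cannot separate the contribution of the piperidine ring from that of its nitrogen, so it stays open whether a morpholin-4-yl ring, a dimethylamino group or a longer chain ending in an amine would do the same at this place. As far as these compounds go, the trifluoromethoxy group is common to compound 3 and compound 4, and it also stays open whether the step would hold with a methoxy group or a chlorine atom in its stead.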